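The source may report more compounds than this note shows. Statements on the series, on what has been measured and on what is new or still open speak of the compounds shown alone.

Of the compounds shown here, two have been measured in a functional assay on HepG2 cells (Homo sapiens) for inhibition, read by MTT assay, with a stated time of 72 h; on this read-out lower numbers stand for stronger inhibition and higher numbers for weaker inhibition. Compound 1 `CN(C(=O)NC(=O)c1ccc(F)c(F)c1)c1nc(C(F)(F)F)c(C(=O)N/N=C/c2cc(C(F)(F)F)cc(C(F)(F)F)c2)s1` gives 5.47 ug/mL in this assay. Compound 2 `CN(C(=O)NC(=O)c1ccc(C(F)(F)F)cc1)c1nc(C(F)(F)F)c(C(=O)N/N=C/c2cccc(C(F)(F)F)c2)s1` gives 7.95 ug/mL in this assay, which is the higher of the two numbers, though the two values sit within the scatter of each other, so no order between them can be claimed. Compound 1 and compound 2 differ in two places, so their values do not isolate a single structural change.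

Compound 3 `CN(C(=O)NC(=O)c1ccc(C(F)(F)F)cc1)c1nc(C(F)(F)F)c(C(=O)N/N=C/c2cc(C(F)(F)F)cc(C(F)(F)F)c2)s1` differs from compound 2 in one place: trifluoromethyl in place of hydrogen on an aromatic carbon. Going by the values given here, no measured pair shows this exact change on its own, so there is no direct step to lean on. The step from compound 2 to compound 3 in this assay is expected to stay within the scatter, with at most a slight lean toward a lower number: a 1.3-fold lower number from compound 2 to compound 3 (0.12 log units; within the scatter). Compound 3 is therefore estimated at 6 ug/mL in this assay, within a range from 3 ug/mL to 12 ug/mL.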

Compound 3, half-maximal inhibitory concentration: 8.35 ug/mL
Estimate against measurement, compound 3: 1.4-fold (0.14 log units) below; the range from low to high includes it.
By their numbers in this assay, from the lowest: compounds 1, 2 and 3 (each within the scatter of the next).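

In this assay, trifluoromethyl in place of hydrogen on an aromatic carbon, meta to a trifluoromethyl group, gives a 1.1-fold higher number from compound 2 to compound 3 (0.02 log units; within the scatter) and so produces no change that can be told apart from repeat-to-repeat variation at this position. The other change, 4-(trifluoromethyl)phenyl in place of 3,4-difluorophenyl on a carbonyl carbon, can now also be read alone: it gives a 1.5-fold higher number from compound 1 to compound 3 (0.18 log units; within the scatter) and also stays within the scatter. Nothing available explains why either change leaves the number so flat.

The compounds shown carry only hydrogen or trifluoromethyl at this position, so it remains open whether an amine or a carboxylic acid there would shift the value beyond the scatter. The same question stands for the ring on the carbonyl carbon, where a nitrile would be a further test.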